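This account rests on a few compounds, and the source may have more. Where it says the series, first, only, none or still open, it means among the compounds named here.

Working notes on the series. Within the data shown here, in a functional assay on the whole organism with Mus musculus as the target (a higher number here means that more compound is needed for the effect, a lower number that less compound is needed), compound 1 `Cc1c(C)c2c(c(C)c1N)CC(C)(C)O2` gives 7.8 mg/kg, the lowest of the numbers measured so far. Compound 3 `COCC1(C)Cc2c(C)c(N)c(C)c(C)c2O1` lies nearest at 20.1 mg/kg. Compound 2 `Cc1c(C)c2c(c(C)c1N)CC(C)(CSCCO)O2` reads > 50 mg/kg, which is a limit of the assay and not a number.

Compound 4 `CCC(=O)Nc1c(C)c(C)c2c(c1C)CC(C)(C)O2` has propanoyl in place of hydrogen on a nitrogen on an aromatic ring. Among the measured compounds shown here, no measured step touches that nitrogen, so the evidence is indirect. The two steps away from compound 1 are a 2.6-fold higher number from compound 1 to compound 3 (0.41 log units; beyond the scatter) and an at least 6.4-fold higher number from compound 1 to compound 2 (0.80 log units; beyond the scatter). Both are changes on a saturated chain carbon bound to a saturated ring carbon, and both raise the number in this assay.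

On that loose guide, a modest rise is expected rather than a fall, though a result within the scatter remains possible: a 2.3-fold higher number from compound 1 to compound 4 (0.36 log units; beyond the scatter) is the expected step. For compound 4 the estimated value is 18 mg/kg, with an expected range of 5 mg/kg to 60 mg/kg.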

Compound 4, dose for 50% inhibition: > 100 mg/kg
Compound 4 ended at the assay's limit; the forecaster's own chance of this, stated with the estimate: 30%; middle value at least 5.5-fold (0.74 log units) away from the limit.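

In this assay, propanoyl in place of hydrogen on a nitrogen on an aromatic ring gives an at least 12-fold higher number from compound 1 to compound 4 (1.10 log units; beyond the scatter), the first step shown at this position and one that shows the nitrogen is also sensitive to change. The earlier steps shown here, a 2.6-fold higher number from compound 1 to compound 3 (0.41 log units; beyond the scatter) and an at least 6.4-fold higher number from compound 1 to compound 2 (0.80 log units; beyond the scatter), touched only a saturated chain carbon bound to a saturated ring carbon and said nothing about the amino group. The reading for compound 4 is a limit and not a number: the limit of > 100 mg/kg in this assay, at which 1 of the 4 values shown sits.

The compounds shown carry only hydrogen or propanoyl on this nitrogen, so they leave open whether the rise belongs to substitution there in general or to propanoyl in particular. A methyl or acetyl group on the nitrogen would bear on that question.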